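The compounds below may be only part of what the source reports. "The series", "measured", "known", "first", "only" and "open" are said of these compounds alone.

Working notes on the series. Compound 1 `C[C@@H](Cn1ccc(-c2ccc(C#N)c(Cl)c2)n1)NC(=O)c1ccccc1` carries a benzoyl group on the amine nitrogen of the shared core and gives 1830 nM in a functional assay on LNCaP cells (Homo sapiens) for antiproliferative activity, read by CCK-8 assay, with a stated time of 6 days; a higher number here means a weaker inhibitor, a lower number a stronger inhibitor. Compound 2 `C[C@@H](Cn1ccc(-c2ccc(C#N)c(Cl)c2)n1)NC(=O)c1cccc(OCC(O)CO)c1` adds 2,3-dihydroxypropoxy on an aromatic carbon of that benzoyl ring; in this assay compound 2 gives 740 nM, and a 2.5-fold lower number from compound 1 to compound 2 (0.39 log units; beyond the scatter). Compound 3 `CC(Cn1ccc(-c2ccc(C#N)c(Cl)c2)n1)C(=O)Nc1cc[nH]n1` rearranges the linkage so that the amide is turned round and an aromatic heterocycle sits on the amide nitrogen; in this assay compound 3 reaches only a limit, > 30000 nM, which is the limit of > 30000 nM in this assay, at which 1 of the 3 values shown sits. Among the numbers given, compound 1 stands highest of the two measured values, with compound 2 as the nearest neighbour.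

Compound 4 `C[C@@H](Cn1ccc(-c2ccc(C#N)c(Cl)c2)n1)NS(=O)(=O)c1cccnc1` differs from compound 1 by (pyridin-3-yl)sulfonyl in place of benzoyl on an amine nitrogen. Among the compounds with values here, no measured step involves this exchange: the only single-place step, from compound 1 to compound 2, alters the benzoyl ring rather than replacing it, and compound 3 is not a one-step neighbour of either. The replacement of the amide carbonyl by a sulfonyl is therefore untested within the series. Compound 4 is expected to sit near compound 1 or somewhat higher, with a step of a 1.6-fold higher number from compound 1 to compound 4 (0.21 log units; within the scatter) estimated. The expected value for compound 4 in this assay is 3000 nM, within 800 nM to 15000 nM.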

Compound 4, half-maximal inhibitory concentration: 6140 nM
Estimate against measurement, compound 4: 2.0-fold (0.31 log units) below, and the stated range covers the measured number.
By their numbers in this assay, from the lowest: compound 2; then compound 1; then compound 4. At a limit, above all of these: compound 3.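

Within the data shown here, exchanging benzoyl for (pyridin-3-yl)sulfonyl on the amine nitrogen gives a 3.4-fold higher number from compound 1 to compound 4 (0.53 log units; beyond the scatter) in this assay, the direction opposite to the one step read so far. This position therefore responds to replacement of the whole benzoyl group, whereas the earlier step showed only a change made on the benzoyl ring. The exchange alters two things at once, carbonyl to sulfonyl and a ring of carbon only to a ring with one hetero atom, and this single step cannot divide its size between them; nothing measured in the series gives a cause for it.

Open, going by these compounds, is whether a phenylsulfonyl group on the same nitrogen, or a pyridine-3-carbonyl group, tracks compound 1 or compound 4, which would separate the linking group from the ring. Also open, on these data alone, is whether 2,3-dihydroxypropoxy, a carboxylic acid or an amine on the (pyridin-3-yl)sulfonyl ring lowers the number as 2,3-dihydroxypropoxy did on the benzoyl ring of compound 2.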